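Removing one acetyl from a trisaccharide ester

The compounds below may be only part of what the source reports. "The series", "measured", "known", "first", "only" and "open" are said of these compounds alone.

Measured compounds in a functional assay on Lu1 cells (Homo sapiens) for cytotoxicity; a higher number here means that more compound is needed for the effect, a lower number that less compound is needed:
Compound 1 `CCCCCCCCO[C@@H]1O[C@@H](C)[C@H](OC(=O)CCCCC)[C@@H](O[C@@H]2O[C@@H](C)[C@H](OC(C)=O)[C@@H](O[C@@H]3O[C@@H](C)[C@H](OC(C)=O)[C@@H](OC(C)=O)[C@H]3O)[C@H]2OC(C)=O)[C@H]1O`: 11.8 ug/mL
Compound 2 `CCCCCCCCO[C@@H]1O[C@@H](C)[C@H](OC(=O)CCCCC)[C@@H](O[C@@H]2O[C@@H](C)[C@H](OC(C)=O)[C@@H](O)[C@H]2OC(C)=O)[C@H]1O`: > 20 ug/mL (a limit of the assay)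
Compound 3 `CCCCCCCCO[C@@H]1O[C@@H](C)[C@H](OC(=O)CCCCC)[C@@H](O[C@@H]2O[C@@H](C)[C@H](OC(C)=O)[C@@H](OC(C)=O)[C@H]2OC(C)=O)[C@H]1O`: 6.1 ug/mL

Compound 3 gives the lowest of the two numbers in this assay. Its nearest neighbour is compound 1, a gap that lies within the scatter, so no order between compound 3 and compound 1 can be read from the data. For compound 2 the assay reports only a limit, and that sits at the limit of > 20 ug/mL in this assay, at which 1 of the 3 values shown sits.

Compound 4 `CCCCCCCCO[C@@H]1O[C@@H](C)[C@H](OC(=O)CCCCC)[C@@H](O[C@@H]2O[C@@H](C)[C@H](O)[C@@H](OC(C)=O)[C@H]2OC(C)=O)[C@H]1O` is not yet measured. It differs from compound 3 by hydrogen in place of acetyl on an oxygen on a saturated carbon.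

Among the measured compounds shown here, only one measured step bears on this change: an at least 3.2-fold lower number from compound 2 to compound 3 (0.51 log units; beyond the scatter). That step introduced an acetyl on a different oxygen and lowered the number; the change from compound 3 to compound 4 removes an acetyl, the opposite direction. For the measured compounds named here, on this basis the number for compound 4 is expected to rise, by roughly a 2.5-fold higher number from compound 3 to compound 4 (0.39 log units; beyond the scatter), though the single supporting step is itself only a limit, so the size is uncertain. The estimate for compound 4 in this assay is 15 ug/mL, with a range from 7 ug/mL to 30 ug/mL, and a fair chance that only a limit is reported.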

Compound 4, concentration for half-maximal effect: 5.4 ug/mL
For compound 4 the middle estimate is 2.8-fold (0.44 log units) above the measured one, outside the stated range (below it).
By their numbers in this assay, from the lowest: compounds 4, 3 and 1 (each within the scatter of the next, the first and the last beyond it). At a limit, above all of these: compound 2.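

In this assay, hydrogen in place of acetyl on this oxygen on a saturated carbon gives a step that cannot be told apart from the usual scatter: a 1.1-fold lower number from compound 3 to compound 4 (0.05 log units; within the scatter). The acetyl at this place is therefore not required for the read-out to stay where compound 3 has it, whereas the acetyl on a different oxygen does make a difference beyond the scatter: an at least 3.2-fold lower number from compound 2 to compound 3 (0.51 log units; beyond the scatter). From the compounds shown here alone, the effect of an acetyl thus depends on which oxygen carries it in these compounds, and the earlier step cannot be carried over to this place; the size of that earlier step stays open, since compound 2 is known only as a limit: the limit of > 20 ug/mL in this assay, at which 1 of the 4 values shown sits.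

The compounds shown leave open whether this oxygen tolerates anything other than acetyl or hydrogen, such as a methyl ether, a longer ester chain like hexanoyl, or an amine in place of the oxygen. They also leave open what happens when the acetyls on both of these oxygens are replaced by hydrogen in one compound.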